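A few compounds are considered here, and "the series" means these few. Any claim that something is new, unique, unknown or untested is made for them only; others in the source may bear on it.

Measured so far:
- compound 1 `COc1ccc(-c2cc(-c3ccc(S(N)(=O)=O)cc3)cnc2N)cn1`: < 7 mL.min-1.g-1
- compound 2 `COc1ccc(-c2cc(-c3ccc(S(C)(=O)=O)cc3C(F)(F)F)cnc2N)cn1`: < 7 mL.min-1.g-1
- compound 3 `COc1ccc(-c2cnc(N)c(-c3ccc(OC)nc3)c2)cn1`: 19.9 mL.min-1.g-1

In an in vitro ADME assay on microsomes from liver (Homo sapiens) for metabolic stability (a higher number here means faster removal of the compound, a lower number slower removal), compound 1 sits at a limit of the assay, < 7 mL.min-1.g-1, and not at a number. Compound 2 also reports only a limit in this assay, < 7 mL.min-1.g-1. Compound 3 gives a number in this assay, 19.9 mL.min-1.g-1. Two of the three values shown thus rest at the limit of < 7 mL.min-1.g-1 in this assay, at which 2 of the 3 values shown sit, so compound 1 cannot be placed relative to compound 2; only compound 3 gives a measured point.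

Compound 4 `COc1ccc(-c2cc(-c3ccc(-n4cccn4)cc3)cnc2N)cn1` carries 1H-pyrazol-1-yl in place of sulfamoyl on an aromatic carbon. Within the data shown here, no step between measured compounds touches this position, so the size of the change is open; a modest rise in this assay is expected, an at least 2.0-fold higher number from compound 1 to compound 4 (0.30 log units; that floor lies within the scatter), within reach of the value of compound 3 19.9 mL.min-1.g-1. Compound 4 is estimated at 14 mL.min-1.g-1, with a range from 5 mL.min-1.g-1 to 40 mL.min-1.g-1.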

Compound 4, intrinsic clearance in microsomes: 9 mL.min-1.g-1
Beside the measured number, compound 4's estimate is 1.6-fold (0.19 log units) above it; low and high end bracket the measured number.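

With 1H-pyrazol-1-yl on this aromatic carbon, compound 4 gives a number and not a limit in this assay. The change from sulfamoyl reads as an at least 1.2-fold higher number from compound 1 to compound 4 (0.10 log units; that floor lies within the scatter), so no step beyond the scatter is shown at this position. The true size of the change stays unread, because compound 1 rests at a limit: the limit of < 7 mL.min-1.g-1 in this assay, at which 2 of the 4 values shown sit.

Still open, as far as these compounds go, is how a nitrile or a morpholine on the same aromatic carbon would read in this assay. Also open, from the compounds shown here alone, is how far sulfamoyl itself lies past its limit.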